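The source may report more compounds than this note shows. Statements on the series, on what has been measured and on what is new or still open speak of the compounds shown alone.

Compounds measured in a functional assay on B16 cells (Mus musculus) for antiproliferative activity, read by MTT assay, with a stated time of 24 h; a higher number here means a weaker inhibitor, a lower number a stronger inhibitor:
- compound 1 `COc1ccc2c(=O)c(-c3cc(OC)c(OC)cc3OC)coc2c1`, which gives 5200 nM
- compound 2 `COc1cccc(C(=O)Oc2ccc3c(=O)c(-c4cc(OC)c(OC)cc4OC)coc3c2)c1`, for which only a limit of the assay is reported: > 10000 nM
- compound 3 `COc1cc(OC)c(-c2coc3cc(OCC(=O)c4cccc(C(F)(F)F)c4)ccc3c2=O)cc1OC`, for which likewise only a limit is reported: > 10000 nM

Compound 3 thus stands at the edge of what this assay can report; it shares that position with one other compound, as noted in the limit of > 10000 nM in this assay, at which 2 of the 3 values shown sit, and so no number marks it. Compound 4 `COc1cc(OC)c(-c2coc3cc(OCc4ccccc4C)ccc3c2=O)cc1OC` differs from it in one place: 2-methylphenyl in place of (3-(trifluoromethyl)phenyl)carbonyl on a saturated chain carbon bound to an oxygen on an aromatic ring. The carbonyl and the trifluoromethyl disappear, and a methyl-bearing ring takes their place on the chain that hangs from the oxygen of the shared core.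

Within the data shown here, no measured step matches this change. The two that exist both start from compound 1: an at least 1.9-fold higher number from compound 1 to compound 2 (0.28 log units; that floor lies within the scatter) and an at least 1.9-fold higher number from compound 1 to compound 3 (0.28 log units; that floor lies within the scatter). Each adds a larger group onto the oxygen position and each reaches only the limit, so they show that growth at this position has not helped. A compound carrying a plain methylphenyl there is expected to behave much like compound 3, giving a step of about an at least 1.2-fold lower number from compound 3 to compound 4 (0.09 log units; that floor lies within the scatter), with a real chance that only a limit is seen again. Compound 4 is therefore estimated at 8000 nM, within 2000 nM to 30000 nM.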

Compound 4, half-maximal inhibitory concentration: 2150 nM
The estimate for compound 4 lay 3.7-fold (0.57 log units) above the measured number, and the stated range covers the measured number.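

The earlier steps shown here showed only larger groups on the oxygen of the shared core reaching the limit in this assay, whereas this result shows that a larger group there can also go with stronger inhibition: a 2.4-fold lower number from compound 1 to compound 4 (0.38 log units; beyond the scatter) is seen when 2-methylphenyl stands in place of hydrogen on the chain carbon. The identity of the group therefore counts, not just the fact that the position is filled, as 2-methylphenyl in place of (3-(trifluoromethyl)phenyl)carbonyl gives an at least 4.6-fold lower number from compound 3 to compound 4 (0.66 log units; beyond the scatter), and 2-methylbenzyl in place of (3-methoxyphenyl)carbonyl on the oxygen gives an at least 4.6-fold lower number from compound 2 to compound 4 (0.66 log units; beyond the scatter). Compound 2 and compound 3 each carry only a limit, so these two steps are floors and their true sizes remain unknown: the limit of > 10000 nM in this assay, at which 2 of the 4 values shown sit.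

Compound 4 differs from compound 3 by losing both the carbonyl and the trifluoromethyl and gaining a methyl, so the compounds shown cannot tell which of these changes accounts for the step. As far as these compounds go, how an amine, a carboxylic acid or a longer chain would behave at this position also remains open.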